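Series notes: variation of the amine substituent on the core

This account rests on a few compounds, and the source may have more. Where it says the series, first, only, none or still open, it means among the compounds named here.

Among the measured compounds shown here, compound 2 `C[C@@H](NC1CCN(CCCc2c[nH]c3ccc(-n4cnnc4)cc23)CC1)c1ccccc1` gives 13 nM in an assay on CHO cells for agonist activity at 5-hydroxytryptamine receptor 1D (Homo sapiens), read by GTPgammaS binding (on this read-out lower numbers stand for an effect already at smaller amounts and higher numbers for an effect only at larger amounts of compound), the highest of the two numbers measured so far; compound 1 `OCCC(NC1CCN(CCCc2c[nH]c3ccc(-n4cnnc4)cc23)CC1)c1ccccc1` gives 5.1 nM. For the measured compounds named here, the one measured step, a 2.5-fold higher number from compound 1 to compound 2 (0.41 log units; beyond the scatter), accompanies a change of the group on the amine nitrogen. Compound 3 `CC(=O)Nc1ccc(CNC2CCN(CCCc3c[nH]c4ccc(-n5cnnc5)cc34)CC2)cc1` differs from compound 2 by 4-acetamidobenzyl in place of 1-phenylethyl on an amine nitrogen. Going by the values given here, no measured step covers this change; the step between compound 1 and compound 2 shows only that variation at this nitrogen shifts the number modestly. A shift of similar or smaller size is expected here, in this assay, with an expected step of a 1.3-fold lower number from compound 2 to compound 3 (0.11 log units; within the scatter). Compound 3 is estimated at 10 nM, with a range from 3 nM to 35 nM.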

Compound 3, half-maximal effective concentration: 5 nM
Beside the measured number, compound 3's estimate is 2.0-fold (0.30 log units) above it; the measured number falls inside the stated range.
By their numbers in this assay, from the lowest: compounds 3 and 1 (each within the scatter of the next); then compound 2.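

In this assay, 4-acetamidobenzyl in place of 1-phenylethyl on this amine nitrogen gives a 2.6-fold lower number from compound 2 to compound 3 (0.41 log units; beyond the scatter), so a change at this position can also lower the number. Against 3-hydroxy-1-phenylpropyl, the same group gives a 1.0-fold lower number from compound 1 to compound 3 (0.01 log units; within the scatter), leaving two quite different groups within the scatter of each other, with compound 2 apart from both. No evidence is available on what lies behind these steps.

Open, going by these compounds, is the part played by the acetamido group, which an unsubstituted benzyl or a 4-aminobenzyl group on the same nitrogen would separate from that of the benzyl part.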